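Pyridyl ether variation and solubility in the benzoic acid series

This account rests on a few compounds, and the source may have more. Where it says the series, first, only, none or still open, it means among the compounds named here.

Values in a physicochemical assay for solubility, read by HPLC, measured as thermodynamic solubility, with a stated time of 4 h, at pH 6.8; a higher number here means a more soluble compound, a lower number a less soluble compound:
compound 1 `Cn1c(COc2cccc(C(=O)O)c2)nc2ccc(Oc3cc(Cl)ccn3)cc21`: 11 ug/mL
compound 2 `Cc1cccc(Oc2ccc3nc(COc4cccc(C(=O)O)c4)n(C)c3c2)n1`: 92 ug/mL
compound 3 `Cc1ccc(C)c(Oc2ccc3nc(COc4cccc(C(=O)O)c4)n(C)c3c2)n1`: 85 ug/mL

Compound 3 stands second highest of the three numbers; its gap to compound 2 is within the scatter (a 1.1-fold lower number from compound 2 to compound 3 (0.03 log units; within the scatter)), while compound 1 sits far lower (a 7.7-fold higher number from compound 1 to compound 3 (0.89 log units; beyond the scatter)). Compound 4 `Cc1cc(F)cnc1Oc1ccc2nc(COc3cccc(C(=O)O)c3)n(C)c2c1` differs from compound 3 in one place: 5-fluoro-3-methylpyridin-2-yl in place of 3,6-dimethylpyridin-2-yl on an oxygen on an aromatic ring. Within the data shown here, no measured step covers a fluorine-bearing pyridyl directly. Among the measured compounds shown here, the steps that bear on the change are an 8.4-fold higher number from compound 1 to compound 2 (0.92 log units; beyond the scatter) and a 7.7-fold higher number from compound 1 to compound 3 (0.89 log units; beyond the scatter), in which the chloro-bearing pyridyl of compound 1 gave a much lower number than either methyl-bearing pyridyl, and a 1.1-fold lower number from compound 2 to compound 3 (0.03 log units; within the scatter), in which a further methyl changed nothing beyond the scatter. Compound 4 keeps one methyl and, like compound 1, carries a halogen on the pyridyl. A step downward from compound 3 is therefore expected in this assay, a 1.9-fold lower number from compound 3 to compound 4 (0.28 log units; within the scatter), smaller than the gap between compound 1 and compound 3 since one methyl remains, though a result within the scatter cannot be excluded. For compound 4 the estimate is 45 ug/mL, with a range from 15 ug/mL to 130 ug/mL.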

Compound 4, solubility: 14 ug/mL
For compound 4 the middle estimate is 3.2-fold (0.51 log units) above the measured one; the whole stated range lies above it.
By their numbers in this assay, from the lowest: compounds 1 and 4 (each within the scatter of the next); then compounds 3 and 2 (each within the scatter of the next).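

In this assay a methyl retained on the pyridyl does not by itself keep the number high: 5-fluoro-3-methylpyridin-2-yl in place of 3,6-dimethylpyridin-2-yl gives a 6.1-fold lower number from compound 3 to compound 4 (0.78 log units; beyond the scatter) and, in place of 6-methylpyridin-2-yl, gives a 6.6-fold lower number from compound 2 to compound 4 (0.82 log units; beyond the scatter) at the same position on the oxygen. The remaining comparison, a 1.3-fold higher number from compound 1 to compound 4 (0.10 log units; within the scatter) for the change from 4-chloropyridin-2-yl, leaves these two halogen-bearing pyridyls unseparated, so the four compounds fall into a low pair and a high pair carrying only methyl groups on the pyridyl, and none of the four goes against that split. No measurement is available here that gives a reason for this split.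

The change from 3,6-dimethylpyridin-2-yl adds a fluorine and removes a methyl at once, so the compounds shown do not separate the contribution of each, and a 3-methylpyridin-2-yl ether would be needed to divide the step. Also open, on these data alone, is how a pyridyl carrying an amine or a methoxy group would stand against the two pairs in this assay on the same core.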